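The source may hold more compounds than are shown below. What is called first, only, known or untested is meant among the compounds shown, and "the series" means these compounds.

Three amides built on a shared bicyclic core have been measured in an assay for inhibition of acyl-CoA:cholesterol acyltransferase (Oryctolagus cuniculus), using microsomes; a higher number here means a weaker inhibitor, a lower number a stronger inhibitor. Compound 1 `CCCCCCCCCCCCCCCC(=O)Nc1cccc2c1OC(C)(C)C2` carries a long straight chain on the amide and gives 890 nM. Compound 2 `CCCCCCCCCCC1(C(=O)Nc2c(C)ccc3c2OC(C)(C)C3)CCCC1` gives 240 nM. Compound 3 `Cc1cc(C)c(NC(=O)C(C)(C)CCCCCc2ccccc2)c2c1CC(C)(C)O2` gives 120 nM, the lowest of the three numbers. Its gap to compound 2 lies within the usual scatter of repeated measurements, so the two cannot be ranked against each other; its gap to compound 1 lies beyond the scatter.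

Compound 4 `Cc1cc(C)c(NC(=O)C(C)(C)CCCCCOc2ccc(Cl)cc2)c2c1CC(C)(C)O2` has not been measured. It differs from compound 3 in one place: 4-chlorophenoxy in place of phenyl on a saturated chain carbon, six bonds along the chain from a carbonyl carbon. The change replaces the aromatic end of the chain with a larger aromatic end that brings an oxygen link and a chlorine. Going by the values given here, no measured pair in this set isolates this kind of change, so the direction of the step rests only on the values shown and on the modest size of the alteration at the far end of the chain.

Compound 4 is therefore expected to land close to compound 3 in this assay, with the step from compound 3 to compound 4 estimated at a 1.2-fold lower number from compound 3 to compound 4 (0.08 log units; within the scatter), which is within the scatter. The estimate for compound 4 is 100 nM, with a range from 40 nM to 300 nM.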

Compound 4, half-maximal inhibitory concentration: 150 nM
Beside the measured number, compound 4's estimate is 1.5-fold (0.18 log units) below it, within the range that was stated.
By their numbers in this assay, from the lowest: compounds 3, 4 and 2 (each within the scatter of the next); then compound 1.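

Going by these compounds alone, the only pair in this set that differs in one place shows what happens when 4-chlorophenoxy takes the place of phenyl on a saturated chain carbon, six bonds along the chain from a carbonyl carbon: in this assay the step is a 1.3-fold higher number from compound 3 to compound 4 (0.10 log units; within the scatter), so the two compounds cannot be told apart. This shows that, on this core and chain, the end of the chain can hold the larger aromatic group, with its oxygen link and chlorine, without a difference that stands out from the scatter of repeated measurements. The earlier compounds differ from one another in more than one place and could not show this, and nothing here explains why the two numbers stay so close.

This swap brings in the oxygen link and the chlorine together, so a plain phenoxy group and a 4-chlorophenyl group at the same place would be needed to separate the two. Also open, as far as these compounds go, is how this assay would respond to an amine or a carboxylic acid at the end of this chain, or to a longer chain.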